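Methyl in place of bromo: 4-bromophenyl to 4-methylphenyl

The source may report more compounds than this note shows. Statements on the series, on what has been measured and on what is new or still open speak of the compounds shown alone.

In a functional assay on T47D cells (Homo sapiens) for cytotoxicity, read by MTT assay, with a stated time of 48 h (on this read-out higher numbers stand for weaker inhibition and lower numbers for stronger inhibition), compound 1 `S=C(N/N=C\c1ccnc2ccccc12)Nc1cccnc1` gives 1100 nM and compound 2 `S=C(N/N=C\c1ccnc2ccccc12)Nc1ccc(Br)cc1` gives 1480 nM. Going by the values given here, these two values lie within the scatter of each other, so compound 2 stands level with the only other measured compound.

Compound 3 `Cc1ccc(NC(=S)N/N=C\c2ccnc3ccccc23)cc1` has methyl in place of bromo on an aromatic carbon, para to a large group: methyl in place of bromo on an aromatic carbon.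

Among the compounds with values here, only one measured step bears on this change, and only indirectly, as it concerns 4-bromophenyl in place of pyridin-3-yl: a 1.3-fold higher number from compound 1 to compound 2 (0.13 log units; within the scatter). That step lies within the scatter. Within the data shown here, no measured step covers bromo and methyl directly, so no change beyond the scatter is expected in this assay, and no direction is favoured.

The expected step is a 1.1-fold lower number from compound 2 to compound 3 (0.06 log units; within the scatter).

For compound 3, the estimated value is 1300 nM, with an expected range of 650 nM to 2600 nM.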

Compound 3, half-maximal inhibitory concentration: 1320 nM
Compound 3: middle estimate off by 1.0-fold (0.01 log units), on the low side, and the stated range covers the measured number.
By their numbers in this assay, from the lowest: compounds 1, 3 and 2 (each within the scatter of the next).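

In this assay, going by these compounds alone, methyl in place of bromo on an aromatic carbon, para to a large group, gives a 1.1-fold lower number from compound 2 to compound 3 (0.05 log units; within the scatter) and is the first direct reading of a change at this position. Setting 4-methylphenyl in place of pyridin-3-yl gives a 1.2-fold higher number from compound 1 to compound 3 (0.08 log units; within the scatter) and so adds a second comparison with compound 1, which leaves compound 1, compound 2 and compound 3 level, with no separation yet among these three groups on the amide-type nitrogen. Nothing measured on these compounds accounts for this flat reading.

As far as these compounds go, whether the flat reading holds for an amine or a carboxylic acid at this position stays open. So does whether a longer chain there, or any change to the shared core, moves the number beyond the scatter in this assay at all.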